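A few compounds are considered here, and "the series" means these few. Any claim that something is new, unique, unknown or untested is made for them only; others in the source may bear on it.

Measured so far:
compound 1 `CS/C(=N\C(=O)c1ccco1)NC(=O)c1ccco1` with > 100000 nM
compound 2 `O=C(/N=C(/NC(=O)c1ccco1)[Se]Cc1ccccc1)c1ccco1` with 76500 nM
compound 3 `CS/C(=N\C(=O)c1cnc2ccccc2c1)NC(=O)c1cnc2ccccc2c1` with > 100000 nM

In a functional assay on HepG2 cells (Homo sapiens) for cytotoxicity, read by MTT assay, with a stated time of 72 h (a lower number here means that less compound is tolerated, a higher number that more compound is tolerated), compound 1 stops at a limit of the assay, > 100000 nM, not a number. Compound 2 gives 76500 nM in this assay. Compound 3 again stops at a limit, > 100000 nM. The change from compound 1 to compound 2 is a group of 8 heavy atoms (7 carbon, 1 selenium; one six-membered aromatic ring of carbon only) in place of a group of 2 heavy atoms (1 carbon, 1 sulfur; no ring), on a carbon with a double bond to nitrogen, and it brought an at least 1.3-fold lower number from compound 1 to compound 2 (0.11 log units; that floor lies within the scatter). The difference between the core of compound 1 and the core of compound 3 is not broken down here. Compound 4 `O=C(/N=C(/NC(=O)c1cnc2ccccc2c1)[Se]Cc1ccccc1)c1cnc2ccccc2c1` carries the same change on the core of compound 3: a group of 8 heavy atoms (7 carbon, 1 selenium; one six-membered aromatic ring of carbon only) in place of a group of 2 heavy atoms (1 carbon, 1 sulfur; no ring), on a carbon with a double bond to nitrogen. The measured step can only be read as a floor because the limit of > 100000 nM in this assay, at which 2 of the 3 values shown sit, hides how far compound 1 truly sits from compound 2. For compound 4 the step expected is an at least 1.2-fold lower number from compound 3 to compound 4 (0.09 log units; that floor lies within the scatter), since the same change gave compound 2 its 76500 nM. The value expected for compound 4 is therefore 80000 nM, somewhere between 40000 nM and 160000 nM, with a real chance that only a limit is reported.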

Compound 4, concentration lethal to 50% of the cells: 90300 nM
Compound 4: the middle estimate sits 1.1-fold (0.05 log units) below what was measured, and the stated range covers the measured number.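

Replacing methylsulfanyl with the larger group that brings in selenium and a six-membered aromatic ring, on the carbon with a double bond to nitrogen, gave in this assay an at least 1.1-fold lower number from compound 3 to compound 4 (0.04 log units; that floor lies within the scatter). On both cores the change leads from a limit to a measured number, which is as far as the two steps can be set side by side: the same change on two cores in this assay, an at least 1.3-fold lower number (0.11 log units; that floor lies within the scatter) from compound 1 to compound 2 and an at least 1.1-fold lower number (0.04 log units; that floor lies within the scatter) from compound 3 to compound 4; the limit leaves it open whether they differ This does not show that the change has the same size on both cores, or that it lowers the number by more than the usual scatter on either, and the true starting points remain hidden by the limit of the assay: the limit of > 100000 nM in this assay, at which 2 of the 4 values shown sit.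

Selenium and the aromatic ring enter together in both steps, and the compounds shown leave open which of them, if either, goes with the measured numbers. A benzyl group on sulfur or a methyl group on selenium at the same carbon would separate the two.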